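Replacing the 1-methylpiperidin-4-yl Group of Compound 2

The source may hold more compounds than are shown below. What is called first, only, known or untested is meant among the compounds shown, and "the series" means these compounds.

In a physicochemical assay for solubility, read by HPLC, in phosphate buffer, measured as kinetic solubility, with a stated time of 1 h, at pH 7.4, tested at 250 uM (on this read-out higher numbers stand for higher solubility and lower numbers for lower solubility), compound 1 `CC(C)N1CCC(c2ccc3c(c2)oc(=O)n3C(=O)NCCCCc2ccccc2)CC1` gives 50000 nM and compound 2 `CN1CCC(c2ccc3c(c2)oc(=O)n3C(=O)NCCCCc2ccccc2)CC1` gives 120000 nM, the higher of the two numbers. Compound 3 `CN1CCN(c2ccc3c(c2)oc(=O)n3C(=O)NCCCCc2ccccc2)CC1=O` carries 4-methyl-3-oxopiperazin-1-yl in place of 1-methylpiperidin-4-yl on an aromatic carbon. Within the data shown here, the only measured step, a 2.4-fold higher number from compound 1 to compound 2 (0.38 log units; beyond the scatter), is modest and concerns just the group on an amine nitrogen in a ring, so it is a rough guide for this exchange of a whole ring. A lower number is expected, estimated as a 2.7-fold lower number from compound 2 to compound 3 (0.43 log units; beyond the scatter). For compound 3 the estimate is 45000 nM, with an expected range of 14000 nM to 130000 nM.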

Compound 3, solubility: < 1000 nM
Compound 3 ended at the assay's limit; the forecaster's own chance of this, stated with the estimate: 10%; middle value at least 45-fold (1.65 log units) from the limit.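

At this position on the aromatic carbon, the ring itself counts for far more than the group on its nitrogen. Putting 4-methyl-3-oxopiperazin-1-yl in place of 1-methylpiperidin-4-yl gives an at least 120-fold lower number from compound 2 to compound 3 (2.07 log units; beyond the scatter), and putting it in place of 1-isopropylpiperidin-4-yl gives an at least 50-fold lower number from compound 1 to compound 3 (1.69 log units; beyond the scatter), both large beside the modest earlier step. The value of compound 3 is a limit of the assay and not a number: the limit of < 1000 nM in this assay, at which 1 of the 3 values shown sits.

The compounds shown leave open whether the drop goes with the ring carbonyl or with the second ring nitrogen. A 4-methylpiperazin-1-yl group, which has that nitrogen but no carbonyl, would separate the two.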